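Removing a hydroxy from compound 1

The compounds below may be only part of what the source reports. "The series", "measured", "known", "first", "only" and "open" are said of these compounds alone.

Of the compounds shown here, three have been tested in an assay on CHO cells for displacement of a labelled ligand from adenosine receptor A1 (Homo sapiens), read by scintillation counting, with a stated time of 60 min, tested at 10 uM; a lower number here means less inhibition, a higher number more inhibition at the concentration tested (going by the name of the read-out). Compound 1 `N=c1oc2ccc(Br)cc2cc1C(=O)NCC(O)CO` gives 11%. Compound 2 `COc1cccc2cc(C(=O)N[C@@H](CO)C(=O)O)c(=O)oc12` gives 12%, and compound 3 `O=C(O)CNC(=O)c1cc2ccccc2oc1=O` gives 1%. The number for compound 1 lies within the usual scatter of both compound 2 and compound 3, so none of the three can be told apart from the others on these readings; all three show little inhibition at the tested concentration.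

Compound 4 `N=c1oc2ccc(Br)cc2cc1C(=O)NCCCO` has not yet been measured. It differs from compound 1 in one place: hydrogen in place of hydroxy on a saturated chain carbon bound to two saturated chain carbons. Within the data shown here, no pair of measured compounds shows this change, so the step has to be guessed. Because compound 1 gives 11% and the change is small, the step of a number 1 percentage points lower from compound 1 to compound 4 (within the scatter) is expected to stay within the scatter. Compound 4 is therefore estimated at 10%, in the range 0% to 22%.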

Compound 4, a percentage reported as inhibition, at one concentration (the size of the read-out at that concentration, not a potency): 32%
Beside the measured number, compound 4's estimate is 22 percentage points below it; the whole stated range lies below it.
By their numbers in this assay, from the lowest: compounds 3, 1 and 2 (each within the scatter of the next, the first and the last beyond it); then compound 4.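

Removing the hydroxy from the saturated chain carbon bound to two saturated chain carbons, which turns 2,3-dihydroxypropyl into 3-hydroxypropyl, gives a number 21 percentage points higher from compound 1 to compound 4 (beyond the scatter) in this assay. So this position is sensitive to what it carries, and a single hydroxy there makes a readable difference on this core. The earlier compounds shown here could not show this, since no two of them differed in one place.

Nothing measured here says why the number moves. Going by these compounds, whether an amine or a fluorine at this carbon would read like hydrogen or like hydroxy stays open, as does the effect of a longer chain.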